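Trading a fluoro for a methyl in compound 3

The source may report more compounds than this note shows. Statements on the series, on what has been measured and on what is new or still open speak of the compounds shown alone.

Compound 1 `O=S(=O)(Nc1ccc(Cl)c(Cl)c1)c1ccc(-c2cnc(C3CC3)o2)cc1` and compound 2 `O=S(=O)(Nc1cc(F)cc(F)c1)c1ccc(-c2cnc(C3CC3)o2)cc1` share a core and differ only in the group on the sulfonamide nitrogen. In a functional assay on cells (leukaemia cell line, Homo sapiens) for inhibition, read by sulforhodamine B assay, with a stated time of 48 h (a higher number here means a weaker inhibitor of growth, a lower number a stronger inhibitor of growth), compound 1 gives 62100 nM and compound 2 gives 80000 nM. Among the measured compounds shown here, these are the only two numbers so far, and they lie within the scatter of each other, so compound 2 cannot be ranked against compound 1. Compound 3 `Cc1cc(F)cc(NS(=O)(=O)c2ccc(-c3cnc(C4CC4)o3)cc2)c1` comes from compound 2 by one change: methyl in place of fluoro on an aromatic carbon. This puts methyl in place of fluoro on an aromatic carbon, turning 3,5-difluorophenyl into 3-fluoro-5-methylphenyl. For the measured compounds named here, the one measured step that bears on this is a 1.3-fold higher number from compound 1 to compound 2 (0.11 log units; within the scatter), with 3,5-difluorophenyl in place of 3,4-dichlorophenyl. A larger replacement on that phenyl stayed within the scatter, so no shift beyond the scatter is expected in this assay. The expected step is a 1.1-fold lower number from compound 2 to compound 3 (0.03 log units; within the scatter). For compound 3 the estimated value is 75000 nM, with an expected range from 45000 nM to 100000 nM.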

Compound 3, concentration for total growth inhibition: 7250 nM
Compound 3: middle estimate off by 10-fold (1.01 log units), on the high side, and the stated range ends above it.
By their numbers in this assay, from the lowest: compound 3; then compounds 1 and 2 (each within the scatter of the next).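

In this assay the phenyl on the sulfonamide nitrogen turns out to be sensitive: methyl in place of fluoro gives an 11-fold lower number from compound 2 to compound 3 (1.04 log units; beyond the scatter), although each group is a single heavy atom and neither brings a hydrogen-bond donor or acceptor. Replacing 3,4-dichlorophenyl with 3-fluoro-5-methylphenyl points the same way, with an 8.6-fold lower number from compound 1 to compound 3 (0.93 log units; beyond the scatter). So a one-atom change on this ring can matter more than the larger replacement that separated the first two compounds, whose numbers stayed within the scatter.

Nothing in the data shown accounts for this gain. From the compounds shown here alone, it also remains open whether the gain is specific to methyl, or whether an ethyl, a methoxy or a second methyl in place of the remaining fluoro would keep it.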